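The compounds below may be only part of what the source reports. "The series", "measured", "known", "first", "only" and "open" are said of these compounds alone.

Measured so far in a functional assay on SK-MEL-28 cells (Homo sapiens) for cytotoxicity, read by CCK-8 assay, with a stated time of 24 h; on this read-out higher numbers stand for weaker inhibition and lower numbers for stronger inhibition:
- compound 1, `COc1ccccc1Oc1c(N)nc(-c2ccc(F)cc2)nc1Cl`, gives 31900 nM
- compound 2, `COc1ccccc1Oc1c(N)nc(-c2cccc(Cl)c2)nc1Cl`, gives 19400 nM
- compound 3, `COc1ccccc1Oc1c(N)nc(-c2ccc(F)cc2)nc1OCCO`, gives 20100 nM

Compound 4, `COc1ccccc1Oc1c(N)nc(-c2cccc(Cl)c2)nc1OCCO`, is not yet measured in this assay. Its core differs from the core of compound 1 as compound 3 does: 2-hydroxyethoxy in place of chloro on an aromatic carbon, a step of a 1.6-fold lower number from compound 1 to compound 3 (0.20 log units; within the scatter). The change from compound 3 to compound 4 is 3-chlorophenyl in place of 4-fluorophenyl on an aromatic carbon. The same kind of change has been measured once, from compound 1 to compound 2: 3-chlorophenyl in place of 4-fluorophenyl on an aromatic carbon, giving a 1.6-fold lower number from compound 1 to compound 2 (0.22 log units; within the scatter). The two places are not identical in their surroundings: in compound 1 the site is meta to a chloro group and para to a group of 9 heavy atoms, in compound 3 it is meta to a 2-hydroxyethoxy group and para to a 2-methoxyphenoxy group, so this is the same kind of change, not the same. Compound 2 and compound 3 give values within the scatter of each other.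

Among the measured compounds shown here, the expected step from compound 3 to compound 4 in this assay is a 1.5-fold lower number from compound 3 to compound 4 (0.19 log units; within the scatter), set beside the earlier step and resting on it, with wide bounds since only one instance is known. Compound 4 is estimated at 13000 nM, with a range from 6000 nM to 30000 nM.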

Compound 4, half-maximal inhibitory concentration: 4170 nM
For compound 4 the middle estimate is 3.1-fold (0.49 log units) above the measured one, outside the stated range (below it).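

In this assay, the change to 3-chlorophenyl from 4-fluorophenyl does not carry over at a constant size from the core of compound 1 to the core of compound 3, where it gives a 4.8-fold lower number from compound 3 to compound 4 (0.68 log units; beyond the scatter): the same change on two cores in this assay, a 1.6-fold lower number (0.22 log units; within the scatter) from compound 1 to compound 2 and a 4.8-fold lower number (0.68 log units; beyond the scatter) from compound 3 to compound 4, 2.9-fold (0.47 log units) apart, beyond the scatter of two such steps. Read the other way, 2-hydroxyethoxy in place of chloro gives a 4.7-fold lower number from compound 2 to compound 4 (0.67 log units; beyond the scatter) when 3-chlorophenyl is present, and the size of this step also depends on its partner: the same change on two cores in this assay, a 1.6-fold lower number (0.20 log units; within the scatter) from compound 1 to compound 3 and a 4.7-fold lower number (0.67 log units; beyond the scatter) from compound 2 to compound 4, 2.9-fold (0.47 log units) apart, beyond the scatter of two such steps. The two changes are therefore not independent across these compounds, but this rests on one set of four compounds and does not show why they interact or whether the same holds on any other core.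

From the compounds shown here alone, it remains open whether the larger steps need the 2-hydroxyethoxy group itself or would also appear with a 2-aminoethoxy group or a longer chain such as 3-hydroxypropoxy. Going by these compounds, it is equally open whether a bromophenyl or an unsubstituted phenyl group would behave like 3-chlorophenyl.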